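Replacing the Aryl Ketone Ring of Compound 1

The source may hold more compounds than are shown below. What is called first, only, known or untested is meant among the compounds shown, and "the series" means these compounds.

Compound 1 `COc1cc(-c2cc(/C=C/C(=O)c3ccc(N)cc3)[nH]n2)cc(OC)c1OC` gives -86% in a functional assay on SN12C cells (Homo sapiens) for cytotoxicity, read by sulforhodamine B assay, with a stated time of 48 h, tested at 100 uM (on this read-out lower numbers stand for a stronger effect and higher numbers for a weaker effect at the one concentration tested), the second highest of the three numbers. Its nearest neighbour is compound 2 `COc1ccc(-c2cc(/C=C/C(=O)c3ccc(N)cc3)[nH]n2)cc1OC`, which in this assay gives -90%; the step of a number 4 percentage points lower from compound 1 to compound 2 (within the scatter) goes with hydrogen in place of methoxy on an aromatic carbon. Compound 3 `COc1ccc(-c2cc(/C=C/C(=O)c3cc(OC)c(OC)c(OC)c3)[nH]n2)cc1OC` gives -67%, a number beyond the scatter from compound 1. Compound 4 `COc1cc(-c2cc(/C=C/C(=O)c3ccc(F)c(F)c3)[nH]n2)cc(OC)c1OC` differs from compound 1 by 3,4-difluorophenyl in place of 4-aminophenyl on a carbonyl carbon. Among the compounds with values here, no measured step changes this ring alone, yet the values of compound 2 and compound 3 show that altering the aryl group on the carbonyl carbon can move the number beyond the scatter. Compound 4 is therefore expected at -75%, between -95% and -50%, an expected step of a number 11 percentage points higher from compound 1 to compound 4 (beyond the scatter).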

Compound 4, a percentage reported as activity, at one concentration (the size of the read-out at that concentration, not a potency): -22%
For compound 4 the middle estimate is 53 percentage points below the measured one; the measured number lies above the stated range.
By their numbers in this assay, from the lowest: compounds 2 and 1 (each within the scatter of the next); then compound 3; then compound 4.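

The change to 3,4-difluorophenyl in place of 4-aminophenyl on a carbonyl carbon goes, in this assay, with a number 64 percentage points higher from compound 1 to compound 4 (beyond the scatter). Within the data shown here, this is the first single change on this ring of compound 1, and it shows that the effect at the one concentration tested depends strongly on the group at this position. Nothing measured accounts for the size of this step.

The compounds shown do not separate losing the amino group from gaining the two fluorines. On these data alone, a plain phenyl or a hydroxyphenyl on the carbonyl carbon remains open.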